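The source may report more compounds than this note shows. Statements on the series, on what has been measured and on what is new or still open speak of the compounds shown alone.

Measured compounds:

Compound 1 `Clc1ccc(OC(CCn2ccnc2)c2ccccc2)cc1` gives 221000 nM in a functional assay on K562 cells (Homo sapiens) for cytotoxicity; a higher number here means that more compound is tolerated, a lower number that less compound is tolerated.
Compound 2 `Cc1ccc(OC(CCn2ccnc2)c2ccccc2)cc1` gives 95900 nM in this assay.
Compound 3 `Cc1ccc(C(CCn2ccnc2)Oc2ccc(Cl)cc2Cl)cc1` gives 31400 nM in this assay.

Among these three numbers compound 2 holds the second highest place; its nearest neighbour is compound 1, whose number is higher by a 2.3-fold lower number from compound 1 to compound 2 (0.36 log units; beyond the scatter) read in the other direction, while compound 3 sits furthest away with a lower number, a gap beyond the scatter.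

Compound 4 `O=[N+]([O-])c1ccc(OC(CCn2ccnc2)c2ccccc2)cc1` carries the change (nitro in place of methyl on an aromatic carbon). Among the compounds with values here, of the measured steps, only the one from compound 1 to compound 2, a 2.3-fold lower number from compound 1 to compound 2 (0.36 log units; beyond the scatter), bears on this change, since it also swaps a group on the same aromatic carbon, and it was modest. Within the data shown here, no measured step pairs methyl against nitro, so the direction is uncertain; the one swap on this carbon, chloro for methyl, moved the number only modestly, and a step of comparable size in either direction, or none beyond the scatter, is expected here. Compound 4 is therefore estimated at 140000 nM in this assay, within 55000 nM to 360000 nM, an expected step of a 1.5-fold higher number from compound 2 to compound 4 (0.16 log units; within the scatter).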

Compound 4, half-maximal cytotoxic concentration: 102000 nM
Compound 4: the middle estimate sits 1.4-fold (0.14 log units) above what was measured, within the range that was stated.
By their numbers in this assay, from the lowest: compound 3; then compounds 2 and 4 (each within the scatter of the next); then compound 1.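

In this assay, nitro and methyl on this aromatic carbon, para to a large group, cannot be told apart: the step is a 1.1-fold higher number from compound 2 to compound 4 (0.03 log units; within the scatter), although nitro has more heavy atoms and brings two hydrogen-bond acceptors. The swap from chloro now gives a 2.2-fold lower number from compound 1 to compound 4 (0.34 log units; beyond the scatter) and sits alongside the earlier 2.3-fold lower number from compound 1 to compound 2 (0.36 log units; beyond the scatter), so of the three groups tried on this carbon, only chloro stands apart, with compound 1 holding the higher number. Nothing measured here accounts for this grouping.

Going by these compounds, whether an amine or a carboxylic acid on this carbon would stay with methyl and nitro or move the number further remains open. Also open, on these data alone, is whether the same swaps would read alike on the core of compound 3 .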